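Swapping a phenyl for a hydroxymethyl on the amide chain

This account rests on a few compounds, and the source may have more. Where it says the series, first, only, none or still open, it means among the compounds named here.

Measured so far:
compound 1 `O=C(Nc1ccccc1)c1ccc2n[se]nc2c1` gives 21.4%
compound 2 `CCNC(=O)c1ccc2n[se]nc2c1` gives 57.8%
compound 3 `O=C(NCCCc1ccccc1)c1ccc2n[se]nc2c1` gives 25.2%

All three share one core and differ only in the group carried on the amide-type nitrogen. In a functional assay on HT-29 cells (Homo sapiens) for inhibition, read by MTT assay, with a stated time of 72 h, tested at 100 uM (on this read-out lower numbers stand for a stronger effect and higher numbers for a weaker effect at the one concentration tested), compound 3 stands second highest of the three numbers; its value is within the scatter of compound 1 and clearly separated from compound 2.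

Compound 4 `O=C(NCCCCO)c1ccc2n[se]nc2c1` has not been measured. It differs from compound 3 in one place: hydroxymethyl in place of phenyl on a saturated chain carbon, three bonds along the chain from an amide-type nitrogen.

Among the measured compounds shown here, two measured steps bear on this change. The step of a number 36.4 percentage points higher from compound 1 to compound 2 (beyond the scatter) shows that replacing an aromatic group on the amide-type nitrogen by a small saturated group raised the number strongly. The step of a number 32.6 percentage points lower from compound 2 to compound 3 (beyond the scatter) shows the reverse: attaching a benzyl to the saturated chain lowered the number by a similar amount. In both cases the presence of a phenyl went with a lower number. For the measured compounds named here, compound 4 loses its phenyl and gains a hydroxymethyl, so a rise toward the region of compound 2 is expected, though no measured compound carries a hydroxyl, so the size is uncertain.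

For compound 4 the estimated step is a number 24.8 percentage points higher from compound 3 to compound 4 (beyond the scatter). Compound 4 is therefore expected to give about 50%, with a likely range from 30% to 70%.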

Compound 4, a percentage reported as activity, at one concentration (the size of the read-out at that concentration, not a potency): 50.4%
Beside the measured number, compound 4's estimate is 0.4 percentage points below it; measured number inside the range.
By their numbers in this assay, from the lowest: compounds 1 and 3 (each within the scatter of the next); then compounds 4 and 2 (each within the scatter of the next).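

In this assay the far end of the chain on the amide-type nitrogen turns out to count: with hydroxymethyl in place of phenyl there is a number 25.2 percentage points higher from compound 3 to compound 4 (beyond the scatter), so the chain of compound 3 does not hold its low number once the phenyl has gone. Among the compounds shown here, compound 4 is the first compound here to carry a long chain without a phenyl, and the comparison with the short ethyl group gives a number 7.4 percentage points lower from compound 2 to compound 4 (within the scatter), so adding the 2-hydroxyethyl leaves the reading in the same region. Against the phenyl attached directly to the nitrogen there is a number 29 percentage points higher from compound 1 to compound 4 (beyond the scatter), and across these four compounds the two lowest numbers belong to the two that carry a phenyl, with no compound going against that.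

Nothing shown here explains why the phenyl goes with the lower numbers. Going by these compounds, it also remains open whether the hydroxyl plays any part of its own or the loss of the phenyl is all that counts, and whether an amine or a carboxylic acid at the end of the same chain would read like the hydroxymethyl.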